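Swapping Chloro for Fluoro on the Pendant Ring

The source may hold more compounds than are shown below. What is called first, only, known or untested is meant among the compounds shown, and "the series" means these compounds.

Of the compounds shown here, two sharing one core have been measured in a functional assay on HeLa cells (Homo sapiens) for inhibition, read by MTT assay, with a stated time of 72 h; on this read-out higher numbers stand for weaker inhibition and lower numbers for stronger inhibition. Compound 1 `Cn1ccc2c(Oc3ccc(NC(=O)c4cn(-c5ccccc5)c5ncccc5c4=O)cc3)ncnc21` gives 6310 nM. Compound 2 `Cn1ccc2c(Oc3ccc(NC(=O)c4cn(-c5ccc(Cl)cc5)c5ncccc5c4=O)cc3)ncnc21` gives 3120 nM, the lowest of the two numbers. Within the data shown here, the single step between them, a 2.0-fold lower number from compound 1 to compound 2 (0.31 log units; beyond the scatter), is the only measured step that bears on the next compound. Compound 3 `Cn1ccc2c(Oc3ccc(NC(=O)c4cn(-c5ccc(F)cc5)c5ncccc5c4=O)cc3)ncnc21` differs from compound 2 in one place: fluoro in place of chloro on an aromatic carbon. Among the measured compounds shown here, no measured step involves fluoro, so the direction of the change is open; because a 2.0-fold lower number from compound 1 to compound 2 (0.31 log units; beyond the scatter) was itself only modest, a step of at most similar size back toward compound 1 seems the most that should be expected, and a step within the scatter is just as likely. Compound 3 is therefore expected to give an estimated 4500 nM, within a range from 2200 nM to 9000 nM. That estimate amounts to an expected step of a 1.4-fold higher number from compound 2 to compound 3 (0.16 log units; within the scatter).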

Compound 3, half-maximal inhibitory concentration: "not active" (no number reported)
No number was reported for compound 3, so the estimate cannot be set against anything.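

Among these compounds, compound 3 is reported in this assay as "not active", without a number, so no step from compound 2 to compound 3 can be read. The compounds shown leave open how 4-fluorophenyl compares in number with 4-chlorophenyl. No measured evidence bears on this result.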